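From 4-hydroxyphenyl to 4-ethylphenyl: working notes on cytotoxicity

The compounds below may be only part of what the source reports. "The series", "measured", "known", "first", "only" and "open" are said of these compounds alone.

Measured in an ADME assay on HEK293 cells (Homo sapiens) for cytotoxicity, read by resazurin assay, with a stated time of 48 h; on this read-out lower numbers stand for higher toxicity in this test and higher numbers for lower toxicity in this test:
- compound 1 `O=S(=O)(Nc1ccc(-c2nc3ccccc3o2)cc1)c1cccc(Cl)c1`: > 100000 nM (a limit)
- compound 2 `O=S(=O)(Nc1ccc(-c2nc3ccccc3o2)cc1)c1ccc(O)cc1`: > 100000 nM (a limit)

Compound 2 stands at > 100000 nM, which is a limit of this assay and not a number. Both measured compounds share this position: the limit of > 100000 nM in this assay, at which 2 of the 2 values shown sit.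

Compound 3 `CCc1ccc(S(=O)(=O)Nc2ccc(-c3nc4ccccc4o3)cc2)cc1` carries ethyl in place of hydroxy on an aromatic carbon, para to a large group (ethyl in place of hydroxy on an aromatic carbon).

Going by the values given here, the only measured step that bears on this change is a step that the two limits leave unreadable from compound 1 to compound 2, with 4-hydroxyphenyl in place of 3-chlorophenyl on a sulfonyl sulfur. It gives no size to carry over, yet neither group moved the read-out off the limit. In this assay no shift beyond the scatter is therefore expected, and the estimated step is a number no higher from compound 2 to compound 3 (the limit leaves the size open). For compound 3 the estimate is 100000 nM, with an expected range of 40000 nM to 150000 nM.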

Compound 3, half-maximal cytotoxic concentration: 82000 nM
Estimate against measurement, compound 3: 1.2-fold (0.09 log units) above; low and high end bracket the measured number.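

Of the three compounds, only compound 3 gives a number and not a limit in this assay, so the series now has one readable value to compare against. In place of hydroxy, ethyl gives an at least 1.2-fold lower number from compound 2 to compound 3 (0.08 log units; that floor lies within the scatter), and in place of 3-chlorophenyl, 4-ethylphenyl gives an at least 1.2-fold lower number from compound 1 to compound 3 (0.08 log units; that floor lies within the scatter); both are floors, and neither floor goes beyond the scatter. Compound 1 and compound 2 stay at a single position, a limit and not a number: the limit of > 100000 nM in this assay, at which 2 of the 3 values shown sit.

The step between the 3-chlorophenyl and 4-hydroxyphenyl groups cannot be read, and the true size of both steps to compound 3 stays undetermined. Also open, from the compounds shown here alone, is whether a longer chain, an amine or a carboxylic acid in place of ethyl would shift the read-out beyond the scatter.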